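Acetyl to carboxy on a weakly active compound

A few compounds are considered here, and "the series" means these few. Any claim that something is new, unique, unknown or untested is made for them only; others in the source may bear on it.

Among the compounds with values here, in a functional assay on Caco-2 cells (Homo sapiens) for antiproliferative activity, with a stated time of 48 h (a higher number here means a weaker inhibitor, a lower number a stronger inhibitor), compound 2 (`CCN(CC)c1ccc(-c2ccc(C(C)=O)cc2)nn1`) gives 15000 nM and holds the lower of the two numbers so far. Compound 1 (`CC(=O)c1ccc(-c2ccc(N3CCCC3)nn2)cc1`) reads 50000 nM by comparison. Compound 3 (`CCN(CC)c1ccc(-c2ccc(C(=O)O)cc2)nn1`) keeps the diethylamino group of compound 2 and differs as follows: hydroxy in place of methyl on a carbonyl carbon with hydroxy in place of methyl on a carbonyl carbon, so acetyl becomes carboxy. Within the data shown here, the only measured step, a 3.3-fold lower number from compound 1 to compound 2 (0.52 log units; beyond the scatter), is modest and swaps pyrrolidin-1-yl for diethylamino, a change at a different place. Among the measured compounds shown here, it offers a rough scale for size but no guide to direction, and no measured compound carries carboxy. A modest shift towards a higher number in this assay is a tentative expectation, and the estimated step is a 2.0-fold higher number from compound 2 to compound 3 (0.30 log units; within the scatter) with real doubt about its sign. For compound 3 the estimate is 30000 nM with 9000 nM to 100000 nM as its expected range.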

Compound 3, half-maximal inhibitory concentration: > 25000 nM
Compound 3: a limit, no number; the forecaster's own chance of this, stated with the estimate: 20%; the middle value is on the limit's open side.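

The reading for compound 3 is a limit and not a number: the limit of > 25000 nM in this assay, at which 1 of the 3 values shown sits. At this position, the carbonyl carbon, putting hydroxy in place of methyl turns acetyl into carboxy and gives an at least 1.6-fold higher number from compound 2 to compound 3 (0.22 log units; that floor lies within the scatter). The step is therefore only a floor and the true gap could be wider, but since that floor does not clear the usual scatter, the result gives no sign that carboxy improves on acetyl in this assay and does not firmly show that it is worse.

Going by these compounds, whether an amide or a methyl ester on this carbonyl carbon would give a lower number remains open. It is also unknown how carboxy would read with pyrrolidin-1-yl in place of diethylamino, so this one step cannot be assumed to carry over to other compounds.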